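The compounds below may be only part of what the source reports. "The series", "measured", "known", "first", "only" and "open" are said of these compounds alone.

Measured so far:
- Compound 1, `COc1cc(OC)c(C(=O)/C=C/c2ccccc2SC)c(OC)c1`: 30%
- Compound 2, `COc1cc(O)c(C(=O)/C=C/c2ccccc2OC)c(OC)c1`: 36%

In a functional assay on PC-3 cells (Homo sapiens), read by fluorescence and BrdU incorporation, with a stated time of 48 h, tested at 10 uM (on this read-out lower numbers stand for a stronger effect and higher numbers for a weaker effect at the one concentration tested), compound 1 gives 30%. In the same assay compound 2 gives 36%. Within the data shown here, of the two numbers, the one for compound 2 stands higher, but the gap to compound 1 is within the usual scatter of this assay, so the two compounds cannot be told apart on these values. The two structures differ in more than one place, so nothing can be said about which difference matters.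

Compound 3, `COc1cc(O)c(C(=O)/C=C/c2ccccc2SC)c(OC)c1`, has not yet been measured in this assay. It is made from compound 2 by one change: methylsulfanyl in place of methoxy on an aromatic carbon. Among the measured compounds shown here, no step of this kind is available between measured compounds, so the expectation rests on how close the two measured values lie. The step from compound 2 to compound 3 in this assay is expected to be small, a number 4 percentage points lower from compound 2 to compound 3 (within the scatter), not beyond the scatter in either direction. For compound 3 the estimated value in this assay is 32%, with a range from 15% to 50%.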

Compound 3, a percentage reported as activity, at one concentration (the size of the read-out at that concentration, not a potency): 35%
The estimate for compound 3 lay 3 percentage points below the measured number; the measured number falls inside the stated range.
By their numbers in this assay, from the lowest: compounds 1, 3 and 2 (each within the scatter of the next).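

In this assay, putting methylsulfanyl in place of methoxy on an aromatic carbon, ortho to a large group, gives a number 1 percentage points lower from compound 2 to compound 3 (within the scatter) and so leaves the two groups indistinguishable at this position on this read-out. The new compound also links to compound 1 through a single change, hydrogen in place of methyl on an oxygen on an aromatic ring, and that step is a number 5 percentage points higher from compound 1 to compound 3 (within the scatter) so the free and the methylated oxygen cannot be told apart here either. No other measurement bears on these results.

The compounds shown leave open whether a different group at the methoxy and methylsulfanyl position, such as an amine or a longer chain like butoxy, would move the number beyond the scatter. It is also open whether any group is needed there at all, as a plain hydrogen on that carbon is not among these compounds, and whether a carboxylic acid in place of the oxygen substituent would change the read-out.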